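Geometric isomer step in the acetylated glycoconjugate series

The source may report more compounds than this note shows. Statements on the series, on what has been measured and on what is new or still open speak of the compounds shown alone.

Two members of the series have numbers in a functional assay on MCF7 cells (Homo sapiens) for cytotoxicity, read by sulforhodamine B assay, with a stated time of 48 h; a lower number here means a stronger inhibitor, a higher number a weaker inhibitor. Compound 1 `COc1ccc(/C=C2\C(=O)N(Cc3cn([C@@H]4O[C@H](COC(C)=O)[C@@H](OC(C)=O)[C@H](OC(C)=O)[C@H]4OC(C)=O)nn3)c3ccccc32)cc1OC` gives 23500 nM in this assay. Compound 2 `CCC/C=C1/C(=O)N(Cc2cn([C@@H]3O[C@H](COC(C)=O)[C@@H](OC(C)=O)[C@H](OC(C)=O)[C@H]3OC(C)=O)nn2)c2ccccc21` gives 22600 nM in this assay. Compound 2 carries the lower of the two numbers, but its nearest neighbour, compound 1, sits so close that the gap lies within the scatter, so no order between them can be read.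

The next compound, compound 3 `CCC/C=C1\C(=O)N(Cc2cn([C@@H]3O[C@H](COC(C)=O)[C@@H](OC(C)=O)[C@H](OC(C)=O)[C@H]3OC(C)=O)nn2)c2ccccc21`, is not yet measured in this assay. Its relation to compound 2 is the two compounds have the same atoms and bonds and differ only in configuration as drawn: 1 of 6 stereo elements differ; a double bond is drawn E in compound 2 and Z in compound 3. No measured pair in the series differs only in the geometry of this double bond, so nothing shown here tells how much such a change moves the number.

Given that both measured compounds sit in the same region of this assay, the step from compound 2 to compound 3 is expected to be small, a 1.0-fold lower number from compound 2 to compound 3 (0.01 log units; within the scatter), with no direction claimed beyond the scatter. Compound 3 is estimated at 22000 nM in this assay, with a range from 7000 nM to 70000 nM.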

Compound 3, half-maximal inhibitory concentration: 25000 nM
Estimate against measurement, compound 3: 1.1-fold (0.06 log units) below; the range from low to high includes it.
By their numbers in this assay, from the lowest: compounds 2, 1 and 3 (each within the scatter of the next).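

In this assay, the first pair differing only in the geometry of this double bond gives a 1.1-fold higher number from compound 2 to compound 3 (0.04 log units; within the scatter), so drawing the propyl-bearing double bond Z rather than E has no readable effect on the number. Putting propyl in place of 3,4-dimethoxyphenyl on a double-bonded chain carbon bound to a double-bonded ring carbon gives a 1.1-fold higher number from compound 1 to compound 3 (0.03 log units; within the scatter), so at this position in this assay, neither the geometry nor this exchange of an aromatic group for a short chain separates the compounds. The geometry reading needs no allowance for any other structural change, and it rests on one point: the fact that compounds 2 and 3 differ only in the configuration as drawn.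

As far as these compounds go, whether the double-bond geometry is equally silent when 3,4-dimethoxyphenyl rather than propyl sits on the chain carbon remains open. Also open, from the compounds shown here alone, is whether a longer chain, or a chain ending in an amine or a carboxylic acid, in place of propyl would take the number beyond the scatter.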